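The source may hold more compounds than are shown below. What is called first, only, known or untested is meant among the compounds shown, and "the series" means these compounds.

Going by the values given here, compound 2 `CS(=O)(=O)Nc1cccc(-c2nc(C(c3ccc(F)cc3)c3ccc(F)cc3)sc2CC(=O)O)c1` is the only compound for which a number is known in an in vitro functional assay on HEK285-7 cells for antagonist activity at prostaglandin D2 receptor 2 (Homo sapiens), read by BRET and beta-arrestin recruitment; a lower number here means a stronger inhibitor, a higher number a weaker inhibitor: compound 2 gives 370 nM. Compound 1 `O=C(O)Cc1sc(C(c2ccccc2)c2ccccc2)nc1-c1ccc(C(F)(F)F)cc1` stands apart at a limit of the assay; in this assay compound 1 gives > 100000 nM, which is a limit and not a number, as the limit of > 100000 nM in this assay, at which 1 of the 2 values shown sits, records. Compound 3 `O=C(O)Cc1sc(C(c2ccc(F)cc2)c2ccc(F)cc2)nc1-c1ccnc(N2CCC2)c1` has not yet been measured. It differs from compound 2 in one place: 2-(azetidin-1-yl)pyridin-4-yl in place of 3-(methanesulfonamido)phenyl on an aromatic carbon. Among the compounds with values here, no measured step exists between compounds that differ in one place, so the size of this change rests on no direct comparison and is an expectation only. Compound 3 is expected to come out somewhat weaker than compound 2, with an expected step of a 2.2-fold higher number from compound 2 to compound 3 (0.33 log units; beyond the scatter), a loss that may reach beyond the usual scatter. Compound 3 is therefore estimated at 800 nM, within an expected range from 150 nM to 5000 nM.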

Compound 3, half-maximal inhibitory concentration: > 100000 nM
Compound 3: only a limit was reported; the forecaster's own chance of this, stated with the estimate: 10%; at least 120-fold (2.09 log units) between middle value and limit.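

In this assay, going by these compounds alone, this result gives the first direct comparison at this position, and the step is large: placing 2-(azetidin-1-yl)pyridin-4-yl where compound 2 carries 3-(methanesulfonamido)phenyl gives an at least 270-fold higher number from compound 2 to compound 3 (2.43 log units; beyond the scatter). The aromatic carbon next to the ring nitrogen is therefore not indifferent to the group it bears, since this one change separates a compound with a measured number from one without. Compound 3 gives a limit and not a number, so the full size of the loss cannot be read: the limit of > 100000 nM in this assay, at which 2 of the 3 values shown sit.

The change replaces the ring and its substituent together, so the compounds shown do not tell which part carries the loss. On these data alone, it remains open whether 3-acetamidophenyl, or a pyridin-4-yl ring bearing a methanesulfonamido group, would keep the value of compound 2.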